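This account rests on a few compounds, and the source may have more. Where it says the series, first, only, none or still open, it means among the compounds named here.

Series notes, shared core of compound 1 `O=C(NO)c1ccc(NCc2nc(-c3ccccc3)nn2-c2ccccc2Cl)cc1`, which in an assay on Sf9 cells for inhibition of protein deacetylase HDAC6 (Homo sapiens), read by fluorescence, with a stated time of 40 min, tested at 100 nM (a higher number here means more inhibition at the concentration tested (going by the name of the read-out), a lower number less inhibition), gives 64.6%. In this assay compound 2 `CCc1ccc(-n2nc(-c3ccccc3)nc2CNc2ccc(C(=O)NO)cc2)cc1` gives 38.3%, and compound 3 `O=C(NO)c1ccc(NCc2nc(-c3ccccc3)nn2-c2cccc(Cl)c2)cc1` gives 62.3%. Compound 3 stands second highest of the three numbers: its nearest neighbour is compound 1, a number 2.3 percentage points lower from compound 1 to compound 3 (within the scatter), and its furthest is compound 2, a number 24 percentage points higher from compound 2 to compound 3 (beyond the scatter). For the measured compounds named here, the only other step, a number 26.3 percentage points lower from compound 1 to compound 2 (beyond the scatter), also lies beyond the scatter.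

Compound 4 `Cc1cccc(-n2nc(-c3ccccc3)nc2CNc2ccc(C(=O)NO)cc2)c1` is the next to be measured in this assay. It differs from compound 3 in one place: methyl in place of chloro on an aromatic carbon. Going by the values given here, no measured pair exchanges one small group for another at the same place on the ring bonded to the aromatic nitrogen; the measured steps compare 2-chlorophenyl, 3-chlorophenyl and 4-ethylphenyl only. Of these, a number 2.3 percentage points lower from compound 1 to compound 3 (within the scatter) shows the number unchanged within the scatter when the chloro is carried on 2-chlorophenyl or on 3-chlorophenyl, while a number 24 percentage points higher from compound 2 to compound 3 (beyond the scatter) and a number 26.3 percentage points lower from compound 1 to compound 2 (beyond the scatter) show the 4-ethylphenyl analogue lower. Methyl for chloro on 3-chlorophenyl is a smaller exchange than either. The step of a number 5.3 percentage points lower from compound 3 to compound 4 (within the scatter) is therefore expected to stay within the scatter, if anything slightly downward. Compound 4 is estimated at 57%, within a range of 40% to 72%.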

Compound 4, a percentage reported as inhibition, at one concentration (the size of the read-out at that concentration, not a potency): 66%
Beside the measured number, compound 4's estimate is 9 percentage points below it; low and high end bracket the measured number.
By their numbers in this assay, from the lowest: compound 2; then compounds 3, 1 and 4 (each within the scatter of the next).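

In this assay, for the compounds shown here, this is the first exchange of one small group for another at one place on the ring bonded to the aromatic nitrogen, and a number 3.7 percentage points higher from compound 3 to compound 4 (within the scatter) gives no separation between chloro and methyl, each of one heavy atom, when meta to a large group. Going by these compounds alone, the comparison with the 2-chlorophenyl analogue, a number 1.4 percentage points higher from compound 1 to compound 4 (within the scatter), adds 3-methylphenyl to the group of aryl substituents that cannot be told apart, whereas a number 27.7 percentage points higher from compound 2 to compound 4 (beyond the scatter) leaves the 4-ethylphenyl analogue as the only low member, so across these compounds the low number does not follow from the absence of chlorine alone. No measured property is available to account for any of these steps.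

The step to the 4-ethylphenyl analogue changes both the group and its place on the ring, so the compounds shown do not separate the effect of the longer chain from that of its place. From the compounds shown here alone, how an amine or a carboxylic acid would read at this place also remains open.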